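Nitro substitution on a formyl-bearing fused core

A few compounds are considered here, and "the series" means these few. Any claim that something is new, unique, unknown or untested is made for them only; others in the source may bear on it.

Compound 1 `Clc1ccc(Cc2nn3cc(-c4ccccc4)nc3s2)cc1` and compound 2 `O=[N+]([O-])c1ccc(-c2cn3nc(Cc4ccc(Cl)cc4)sc3n2)cc1` share a core, and compound 2 differs only by nitro in place of hydrogen on an aromatic carbon. In an ADME assay on CCRF-CEM cells (Homo sapiens) for cytotoxicity, with a stated time of 72 h (a lower number here means a stronger inhibitor, a higher number a weaker inhibitor), compound 1 gives > 250000 nM, which is a limit of the assay and not a number. Compound 2 likewise gives > 250000 nM, also a limit. The step that the two limits leave unreadable from compound 1 to compound 2 therefore cannot be sized, because both values sit at the limit of > 250000 nM in this assay, at which 2 of the 3 values shown sit.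

Compound 3 `O=Cc1c(-c2ccccc2)nc2sc(Cc3ccc(Cl)cc3)nn12` differs from compound 1 by formyl in place of hydrogen on an aromatic carbon; this is how the two cores differ. In this assay, going by the values given here, compound 3 gives 22000 nM, the only true number among the three. The step of an at least 11-fold lower number from compound 1 to compound 3 (1.05 log units; beyond the scatter) is large.

Among the compounds with values here, compound 4 `O=Cc1c(-c2ccc([N+](=O)[O-])cc2)nc2sc(Cc3ccc(Cl)cc3)nn12` is not yet measured and differs from compound 3 by nitro in place of hydrogen on an aromatic carbon, the same change as the one from compound 1 to compound 2. For compound 4 the expected value is 25000 nM, within 8000 nM to 90000 nM. This estimate means a step of a 1.1-fold higher number from compound 3 to compound 4 (0.06 log units; within the scatter), resting on the unreadable step that the two limits leave unreadable from compound 1 to compound 2 giving no direction, so a value near that of compound 3 is expected.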

Compound 4, half-maximal inhibitory concentration: 13000 nM
Compound 4: middle estimate off by 1.9-fold (0.28 log units), on the high side, and the stated range covers the measured number.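

On the formyl-bearing core, the nitro change can be read in this assay: it gives a 1.7-fold lower number from compound 3 to compound 4 (0.23 log units; within the scatter), so this pair cannot be told apart. The same nitro change on the core without the formyl group cannot be read, so nothing here shows that nitro behaves alike on both cores. The formyl change gives an at least 19-fold lower number from compound 2 to compound 4 (1.28 log units; beyond the scatter), which makes it large on the nitro-bearing core as well as on the core of compound 1, yet the two sizes cannot be set against each other: the same change on two cores in this assay, an at least 11-fold lower number (1.05 log units; beyond the scatter) from compound 1 to compound 3 and an at least 19-fold lower number (1.28 log units; beyond the scatter) from compound 2 to compound 4; the limit leaves it open whether they differ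

The compounds shown leave open whether a measurable value in this assay depends on the formyl group itself or would also appear with a carboxylic acid or an amine on that same aromatic carbon. They also leave open what an amine or a methoxy group would do in place of the nitro group, on a core with the formyl group or on one without it.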